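The source may report more compounds than this note shows. Statements on the series, on what has been measured and on what is new or still open speak of the compounds shown alone.

Compound 3 `O=[N+]([O-])c1ccc(CN2CCC(n3cc(CC(OCc4cc(-c5cccc(Br)c5)no4)c4ccc(Br)cc4)nn3)CC2)cc1` was examined in a functional assay on Caco-2 cells (Homo sapiens) for cytotoxicity, with a stated time of 48 h (a higher number here means a weaker inhibitor, a lower number a stronger inhibitor), where compound 3 gives 5000 nM. Among the three compounds measured so far this is the highest number. Compound 1 `COc1ccc(-c2cc(COC(Cc3cn(C4CCN(Cc5ccc([N+](=O)[O-])cc5)CC4)nn3)c3ccc(Br)cc3)on2)cc1` gives 3000 nM in this assay, and compound 2 `N#Cc1ccc(-c2cc(COC(Cc3cn(C4CCN(Cc5ccc([N+](=O)[O-])cc5)CC4)nn3)c3ccc(Br)cc3)on2)cc1` gives 2000 nM. The step of a 1.7-fold higher number from compound 1 to compound 3 (0.22 log units; within the scatter) lies within the scatter, while a 2.5-fold higher number from compound 2 to compound 3 (0.40 log units; beyond the scatter) is a modest step beyond it.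

Compound 4 `O=[N+]([O-])c1ccc(CN2CCC(n3cc(CC(OCc4cc(-c5cccc(F)c5)no4)c4ccc(Br)cc4)nn3)CC2)cc1` has not been measured. Relative to compound 3 the change is fluoro in place of bromo on an aromatic carbon. Going by the values given here, none of the measured steps exchanges one halogen for another on that ring; the closest precedents alter the same outer aromatic ring in other ways. The step of a 1.5-fold lower number from compound 1 to compound 2 (0.18 log units; within the scatter) stayed within the scatter, and a 1.7-fold higher number from compound 1 to compound 3 (0.22 log units; within the scatter) did too; only a 2.5-fold higher number from compound 2 to compound 3 (0.40 log units; beyond the scatter) exceeded it, and modestly. All three changes at this ring therefore moved this assay little. A step of similar or smaller size is expected for compound 4, with no firm direction, and most likely not beyond the scatter.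

On that basis compound 4 is estimated at 6000 nM, within a range from 2500 nM to 15000 nM, which corresponds to an expected step of a 1.2-fold higher number from compound 3 to compound 4 (0.08 log units; within the scatter).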

Compound 4, half-maximal inhibitory concentration: 5000 nM
Compound 4: middle estimate off by 1.2-fold (0.08 log units), on the high side; low and high end bracket the measured number.
By their numbers in this assay, from the lowest: compounds 2, 1, 3 and 4 (each within the scatter of the next, the first and the last beyond it).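

In this assay, going by these compounds alone, the exchange of bromo for fluoro, the first swap of one halogen for another on this outer ring, gives no change at the digits printed from compound 3 to compound 4 (within the scatter) and so the read-out does not separate these two halogens at this place. Within the data shown here, compound 4 also keeps the relations that compound 3 has with the other two compounds: the comparison with the 4-methoxyphenyl group gives a 1.7-fold higher number from compound 1 to compound 4 (0.22 log units; within the scatter) and stays within the scatter, while the comparison with the 4-cyanophenyl group gives a 2.5-fold higher number from compound 2 to compound 4 (0.40 log units; beyond the scatter) and is the only one of the new steps beyond it, and only modestly. Nothing available accounts for this insensitivity to the halogen.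

The compounds shown leave open whether a group of a different kind at the same place on the ring, such as an amine or a carboxylic acid, would move the number any further than the halogens did. They also leave open whether an unsubstituted phenyl would sit with compound 3 and compound 4, and whether the same indifference to the halogen would hold with the 4-bromo group on the other aromatic ring replaced.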